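This account rests on a few compounds, and the source may have more. Where it says the series, first, only, none or still open, it means among the compounds named here.

Compound 1 `O=C1Nc2ccccc2/C1=N/NC(=S)Nc1ccccc1`: 1470 nM
Compound 2 `O=C1Nc2ccccc2/C1=N/NC(=S)Nc1ccc(F)cc1`: 1920 nM

Both values come from a functional assay on KB-V1 cells (Homo sapiens) for cytotoxicity, read by MTT assay, with a stated time of 72 h; a higher number here means a weaker inhibitor, a lower number a stronger inhibitor. Within the data shown here, compound 2 stands within the scatter of compound 1, its only neighbour on these numbers. Compound 3 `CN(C)c1ccc(NC(=S)N/N=C2\C(=O)Nc3ccccc32)cc1` has dimethylamino in place of fluoro on an aromatic carbon. Among the measured compounds shown here, the one measured step that bears on this is fluoro in place of hydrogen on an aromatic carbon, a 1.3-fold higher number from compound 1 to compound 2 (0.12 log units; within the scatter). That single small step is thin support, but it gives no ground to expect a large move in this assay. The expected step is a 1.5-fold lower number from compound 2 to compound 3 (0.17 log units; within the scatter), with no firm direction expected beyond the scatter. Compound 3 is estimated at 1300 nM, within an expected range of 450 nM to 3800 nM.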

Compound 3, half-maximal inhibitory concentration: 2320 nM
The estimate for compound 3 lay 1.8-fold (0.25 log units) below the measured number, within the range that was stated.
By their numbers in this assay, from the lowest: compounds 1, 2 and 3 (each within the scatter of the next).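

Dimethylamino in place of fluoro gives a 1.2-fold higher number from compound 2 to compound 3 (0.08 log units; within the scatter) in this assay, and dimethylamino in place of hydrogen gives a 1.6-fold higher number from compound 1 to compound 3 (0.20 log units; within the scatter) in the same assay. Among these compounds, this position on the aromatic ring therefore holds hydrogen, fluoro or the larger dimethylamino, with its hydrogen-bond acceptor, and no pair of the three compounds separates beyond the scatter. Nothing available explains this result. From the compounds shown here alone, it remains open whether a carboxylic acid, a primary amine or a longer alkyl chain at this position would stand apart, and whether a change elsewhere on the shared core would do so.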